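Swapping Oxime Geometry in a Dopamine Receptor Efficacy Series

This account rests on a few compounds, and the source may have more. Where it says the series, first, only, none or still open, it means among the compounds named here.

Two oxime derivatives have been tested in a functional assay on HEK293 cells with D(4) dopamine receptor (Homo sapiens) as the target, read by FLIPR; on this read-out higher numbers stand for larger maximal responses and lower numbers for smaller maximal responses. Compound 1 `O/N=C(/CCCN1CCN(c2ccccn2)CC1)c1ccc(F)cc1` carries a free oxime and reaches 65% in this assay. Compound 2 `CO/N=C(\CCCN1CCN(c2ccccn2)CC1)c1ccc(F)cc1` carries a methylated oxime and reaches 60%, the lower of the two numbers shown, though the number for compound 1 lies only a few points higher and the two results sit within the scatter of one another. Compound 3 `CO/N=C(/CCCN1CCN(c2ccccn2)CC1)c1ccc(F)cc1` has not yet been measured. Relative to compound 2 the change is the two compounds have the same atoms and bonds and differ only in configuration as drawn: 1 of 1 stereo elements differ; a double bond is drawn E in compound 2 and Z in compound 3. Among the compounds with values here, no measured step of this kind exists in the set, so the expected step from compound 2 to compound 3 is estimated at no change at the digits printed from compound 2 to compound 3 (within the scatter), that is, no shift beyond the scatter in either direction. Compound 3 is therefore expected to give 60%, with a range from 42% to 78%.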

Compound 3, largest response reached (reported as efficacy), in percent of the reference or control that the assay uses: 59%
For compound 3 the middle estimate is 1 percentage points above the measured one; measured number inside the range.
By their numbers in this assay, from the lowest: compounds 3, 2 and 1 (each within the scatter of the next).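

Turning the double bond of the methylated oxime from E to Z gives a number 1 percentage points lower from compound 2 to compound 3 (within the scatter) in this assay, so this read-out does not separate the two geometries. The pair tests that one feature alone: the fact that compounds 2 and 3 differ only in the configuration as drawn

Methyl in place of hydrogen on the oxygen, compared at the same drawn geometry, gives a number 6 percentage points lower from compound 1 to compound 3 (within the scatter), the first comparison of that change alone, and it also stays inside the scatter.

The compounds shown leave open whether a different group on the oxime oxygen, such as an ethyl or a benzyl, would shift the maximal response beyond the scatter. They also leave open whether the E and Z forms would stay this close with such a group in place of the methyl.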